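Swapping the Sulfonyl Aryl Substituent: Cyano to Fluoro

A few compounds are considered here, and "the series" means these few. Any claim that something is new, unique, unknown or untested is made for them only; others in the source may bear on it.

For the measured compounds named here, compound 2 `COc1ccc(-c2cc(=O)c3c(OC)cc(OC)cc3n2S(=O)(=O)c2ccc(C#N)cc2)cc1` is the one member of this small set with a number rather than a limit. In a functional assay on SUP-B15 cells (Homo sapiens) for antiproliferative activity, with a stated time of 72 h (on this read-out higher numbers stand for an effect only at larger amounts of compound and lower numbers for an effect already at smaller amounts), compound 2 gives 7900 nM. Compound 1 `COc1ccc(-c2cc(=O)c3c(OC)cc(OC)cc3n2S(=O)(=O)c2cccc([N+](=O)[O-])c2)cc1` differs from it only in the aryl group on the sulfonyl sulfur. Compound 1 gives > 39600 nM in this assay, which is a limit of the assay and not a number. The step of an at least 5.0-fold lower number from compound 1 to compound 2 (0.70 log units; beyond the scatter) shows that the substituent on this ring can move the read-out beyond the scatter; that reading rests on (the limit of > 39600 nM in this assay, at which 1 of the 2 values shown sits). Compound 3 `COc1ccc(-c2cc(=O)c3c(OC)cc(OC)cc3n2S(=O)(=O)c2ccc(F)cc2)cc1` carries the change (fluoro in place of cyano on an aromatic carbon). Going by the values given here, only the step from compound 1 to compound 2 bears on it, and it concerns a different substituent, so the direction remains open. The number for compound 3 is expected to sit near or somewhat above that of compound 2, an estimated step of a 1.5-fold higher number from compound 2 to compound 3 (0.18 log units; within the scatter). Compound 3 is therefore estimated at 12000 nM, within 4000 nM to 40000 nM.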

Compound 3, half-maximal effective concentration: > 65500 nM
Compound 3: no number, only a limit (the forecaster's own chance of this, stated with the estimate: 25%); middle value at least 5.4-fold (0.73 log units) away from the limit.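

The change from cyano to fluoro on this aromatic carbon gives an at least 8.2-fold higher number from compound 2 to compound 3 (0.91 log units; beyond the scatter), so a single small replacement at this place, with the rest of the molecule unchanged, is enough to move the read-out beyond the scatter. In this assay compound 3 gives > 65500 nM, which is a limit of the assay and not a number, and the reading of this step rests on it: the limit of > 65500 nM in this assay, at which 1 of the 3 values shown sits. Compound 2 therefore remains the only one of the three with a number, and the step between the other two cannot be read.

The compounds shown leave open whether a group other than cyano at this place, such as an amine, a carboxylic acid or a primary amide, would also give a number in this assay. They also leave open whether cyano would keep that number at another place on the same ring.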